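The source may hold more compounds than are shown below. What is called first, only, known or untested is meant among the compounds shown, and "the series" means these compounds.

Compound 1 `O=C(CN(c1nc(Cl)nc2[nH]cnc12)C1CC1)N[C@@H](CO)C(=O)OCc1ccccc1` gives 34.5% in a functional assay on the whole organism (Tail, strain ICR) with Mus musculus as the target, in the tail flick test, with a stated time of 90 min, at a dose of 25 umol/kg by the oral route; a lower number here means a weaker effect, a higher number a stronger effect of the compound at the dose given.
Compound 2 `C[C@H](NC(=O)CN(c1nc(Cl)nc2[nH]cnc12)C1CC1)C(=O)OCc1ccccc1` gives 44.2% in this assay.
Compound 3 `O=C(CN(c1nc(Cl)nc2[nH]cnc12)C1CC1)NCC(=O)OCc1ccccc1` gives 27.2% in this assay.

Compound 3 sits at the low end of these three numbers. Its gap to compound 1 is within the scatter, so the two cannot be told apart, while its gap to compound 2 is beyond the scatter, as the step of a number 17 percentage points lower from compound 2 to compound 3 (beyond the scatter) shows.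

Compound 4 `CC(C)[C@H](NC(=O)CN(c1nc(Cl)nc2[nH]cnc12)C1CC1)C(=O)OCc1ccccc1` has not yet been measured in this assay. It differs from compound 3 by isopropyl in place of hydrogen on a saturated chain carbon bound to an amide-type nitrogen and a carbonyl carbon. Going by the values given here, the one measured step that bears on this place is a number 17 percentage points lower from compound 2 to compound 3 (beyond the scatter), where hydrogen replaced methyl. Read in the opposite direction, putting a methyl back on that carbon raised the read-out by a modest amount. Among the compounds with values here, an isopropyl is a larger group at the same place, and no measured compound shows what a group of that size does here, so the expectation rests on the methyl step alone. A rise of about the same size is expected, a number 16.8 percentage points higher from compound 3 to compound 4 (beyond the scatter), leading to an estimated value for compound 4 of 44%, between 28% and 60%.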

Compound 4, a percentage reported as activity, at one dose (the size of the read-out at that dose, not a potency): 51.3%
Compound 4: middle estimate off by 7.3 percentage points, on the low side; the measured number falls inside the stated range.
By their numbers in this assay, from the lowest: compounds 3, 1, 2 and 4 (each within the scatter of the next, the first and the last beyond it).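

Isopropyl on this saturated chain carbon bound to an amide-type nitrogen and a carbonyl carbon gives a number 24.1 percentage points higher from compound 3 to compound 4 (beyond the scatter), so a group of this size is tolerated at this place in this assay and the read-out does not fall. Replacing methyl with isopropyl gives a number 7.1 percentage points higher from compound 2 to compound 4 (within the scatter), so the larger group cannot be told apart from methyl here. Against hydroxymethyl, isopropyl gives a number 16.8 percentage points higher from compound 1 to compound 4 (beyond the scatter), which is a clear gap, whereas the methyl step from that same compound stayed within the scatter.

Going by these compounds, whether a longer chain, a benzyl group or an amine at this carbon would raise the number further, hold it level or lower it remains open. Nothing shown here gives a reason for these differences.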